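A methyl added to the propyl chain

The compounds below may be only part of what the source reports. "The series", "measured", "known", "first", "only" and "open" are said of these compounds alone.

Values in a functional assay on brain (Rattus norvegicus, strain Wistar) for inhibition (on this read-out lower numbers stand for stronger inhibition and higher numbers for weaker inhibition), so far:
compound 1 `CCCCc1ccc(-c2c(C)[nH]c(=O)n2C)cc1` gives 10700 nM
compound 2 `CCCCOc1ccc(-c2c(C)[nH]c(=O)n2C)cc1` gives 5100 nM
compound 3 `CCCc1ccc(-c2c(C)[nH]c(=O)n2C)cc1` gives 21500 nM

Compound 3 cannot be told apart from compound 1, with a 2.0-fold higher number from compound 1 to compound 3 (0.30 log units; within the scatter) between them, and it inhibits more weakly than compound 2, with a 4.2-fold higher number from compound 2 to compound 3 (0.62 log units; beyond the scatter) as the gap. Compound 4 `Cc1[nH]c(=O)n(C)c1-c1ccc(CC(C)C)cc1` comes from compound 3 by one change methyl in place of hydrogen on a saturated chain carbon bound to two saturated chain carbons which reads methyl in place of hydrogen on a saturated chain carbon bound to two saturated chain carbons, or propyl to isobutyl. The closest guide is compound 1, whose chain also differs from that of compound 3 by one methyl, though at another place. There a 2.0-fold higher number from compound 1 to compound 3 (0.30 log units; within the scatter) stayed within the scatter, and the number was higher without the methyl. Among the compounds with values here, no measured compound carries isobutyl, so the estimate is uncertain. A small step is therefore expected, estimated as a 1.8-fold lower number from compound 3 to compound 4 (0.25 log units; within the scatter) and probably within the scatter. Compound 4 is expected to read 12000 nM in this assay with an estimated range from 5500 nM to 25000 nM around that middle.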

Compound 4, half-maximal inhibitory concentration: 7800 nM
Beside the measured number, compound 4's estimate is 1.5-fold (0.19 log units) above it; measured number inside the range.
By their numbers in this assay, from the lowest: compounds 2, 4, 1 and 3 (each within the scatter of the next, the first and the last beyond it).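

Placing a methyl on the saturated chain carbon bound to two saturated chain carbons gives a modest but real change in this assay (with a 2.8-fold lower number from compound 3 to compound 4 (0.44 log units; beyond the scatter)), so a single added carbon on this chain can register beyond the scatter. The isobutyl chain cannot be told apart from the unbranched butyl chain (with a 1.4-fold lower number from compound 1 to compound 4 (0.14 log units; within the scatter)), so at this chain size the branch shows no measurable difference. Nor can it be told apart from the butoxy group (with a 1.5-fold higher number from compound 2 to compound 4 (0.18 log units; within the scatter)), even though butyl and butoxy themselves differ beyond the scatter. Nothing available explains why the added methyl changes the number. As far as these compounds go, it also remains open whether a longer branched chain, or an amine or carboxylic acid at the end of the chain, would push inhibition further in either direction.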